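Swapping 4-(ethylsulfanyl)phenyl for 3-hydroxy-4-methoxyphenyl

This account rests on a few compounds, and the source may have more. Where it says the series, first, only, none or still open, it means among the compounds named here.

In a functional assay on HL-60 cells (Homo sapiens) for inhibition, read by resazurin assay, with a stated time of 72 h (a lower number here means a stronger inhibitor, a higher number a weaker inhibitor), compound 1 (`COc1ccc(C2C(O)C(=O)N2c2cc(OC)c(OC)c(OC)c2)cc1`) gives 13 nM and compound 2 (`CCSc1ccc(C2C(O)C(=O)N2c2cc(OC)c(OC)c(OC)c2)cc1`) gives 16 nM, so compound 2 stands level with compound 1. Compound 3 (`COc1ccc(C2C(O)C(=O)N2c2cc(OC)c(OC)c(OC)c2)cc1O`) differs from compound 2 by 3-hydroxy-4-methoxyphenyl in place of 4-(ethylsulfanyl)phenyl on a saturated ring carbon. Within the data shown here, the one measured step on this aryl group, a 1.2-fold higher number from compound 1 to compound 2 (0.09 log units; within the scatter), lies within the scatter. Among the measured compounds shown here, no measured compound carries the aryl hydroxy group, so no step beyond the scatter is expected in this assay, in either direction. The estimated step is a 1.6-fold lower number from compound 2 to compound 3 (0.20 log units; within the scatter). Compound 3 is expected at 10 nM, with an estimated range of 3 nM to 35 nM.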

Compound 3, half-maximal inhibitory concentration: 5 nM
Compound 3: middle estimate off by 2.0-fold (0.30 log units), on the high side; low and high end bracket the measured number.
By their numbers in this assay, from the lowest: compound 3; then compounds 1 and 2 (each within the scatter of the next).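

a 3.2-fold lower number from compound 2 to compound 3 (0.51 log units; beyond the scatter) is the first change of the aryl group on the saturated ring carbon to lie beyond the scatter in this assay and so shows that this position can respond. a 2.6-fold lower number from compound 1 to compound 3 (0.41 log units; beyond the scatter) comes from adding the hydroxy group alone, so the 3-hydroxy-4-methoxyphenyl group gives the lowest number of the three. Nothing measured here gives a reason for either step.

Open, on these data alone, is whether an amino group or a fluorine in place of the aryl hydroxy group would hold the lower number. Also open, as far as these compounds go, is whether a hydroxy group added to the 4-(ethylsulfanyl)phenyl of compound 2 would lower the number too.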